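The source may hold more compounds than are shown below. What is called first, only, known or untested is meant among the compounds shown, and "the series" means these compounds.

Measured compounds:
Compound 1 `COc1cccc(C(=C/C=C/C(=O)NCCCCc2cccnc2)c2cccc(OC)c2)c1` — 2 nM
Compound 2 `COc1ccc(C(=C/C=C/C(=O)Nc2ccc(-c3cccnc3)cc2)c2ccc(OC)cc2)cc1` — 10 nM
Compound 3 `COc1ccc(C(=C/C=C/C(=O)N[C@@H](CCCc2cccnc2)C2CC2)c2ccc(OC)cc2)cc1` — 60 nM

In an assay (Canis lupus familiaris) for binding affinity to platelet-activating factor receptor (Homo sapiens), read by radioligand binding (on this read-out lower numbers stand for stronger inhibition and higher numbers for weaker inhibition), compound 1 gives 2 nM, the lowest number among the three measured compounds. The nearest neighbour of compound 1 on this read-out is compound 2, which gives 10 nM, a gap that lies beyond the usual scatter, and compound 3 gives 60 nM, further away still. Compound 1 therefore stands as the most potent of the three.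

Compound 4 `COc1cccc(C(=C/C=C/C(=O)N[C@H](C)CCCc2cccnc2)c2cccc(OC)c2)c1` has not yet been measured. It differs from compound 1 in one place: methyl in place of hydrogen on a saturated chain carbon bound to an amide-type nitrogen and a saturated chain carbon. The shared core of compound 1, its two methoxy-bearing rings, the diene amide and the 4-(pyridin-3-yl)butyl chain all remain unchanged. Among the compounds with values here, no measured pair shows exactly this change, so the size of the step is uncertain. Compound 3 carries a branch on the carbon bound to the amide nitrogen and gives a higher number than compound 1, but it differs in other places too, so its values only hint at a direction. A modest weakening is expected for the step from compound 1 to compound 4, a 2.5-fold higher number from compound 1 to compound 4 (0.40 log units; beyond the scatter), within or just beyond the scatter. Compound 4 is expected to give about 5 nM in this assay, with a plausible range from 1.5 nM to 20 nM.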

Compound 4, half-maximal inhibitory concentration: 35 nM
The estimate for compound 4 lay 7.0-fold (0.85 log units) below the measured number; measured number above the stated range.
By their numbers in this assay, from the lowest: compound 1; then compound 2; then compounds 4 and 3 (each within the scatter of the next).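

In this assay, within the data shown here, turning 4-(pyridin-3-yl)butyl into 1-methyl-4-(pyridin-3-yl)butyl gives an 18-fold higher number from compound 1 to compound 4 (1.24 log units; beyond the scatter) and is the first change here that can be read in one place alone. It shows that this saturated chain carbon, bound to an amide-type nitrogen, is sensitive: one added carbon, with no ring and no hydrogen-bond donor or acceptor, produces a large step. No measurement at hand explains the size of this step.

The compounds shown leave open whether the mirror-image arrangement of the methyl on this carbon would give a similar step. They also leave open how an ethyl or a hydroxyl on the same carbon would compare, and whether a step of this size would recur on another core.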